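A few compounds are considered here, and "the series" means these few. Any claim that something is new, unique, unknown or untested is made for them only; others in the source may bear on it.

In a functional assay on PC-3 cells (Homo sapiens) for cytotoxicity, read by MTT assay, with a stated time of 72 h (on this read-out higher numbers stand for weaker inhibition and lower numbers for stronger inhibition), compound 1 (`O=C(N/N=C/c1ccc(F)cc1)Nc1cc2c(Nc3ccc(F)c(Cl)c3)ncnc2cc1O[C@H]1CCOC1`) reads "not active" (no number reported), compound 2 (`O=C(N/N=C/c1cccc(Br)c1)Nc1cc2c(Nc3ccc(F)c(Cl)c3)ncnc2cc1O[C@H]1CCOC1`) gives 15500 nM, and compound 3 (`COc1cc2ncnc(Nc3ccc(F)c(Cl)c3)c2cc1NC(=O)N/N=C/c1cccc(Br)c1`) reads "not active" (no number reported). Compound 3 therefore has no single number and stands with compound 1 among the entries without one. Compound 4 (`COc1cc2ncnc(Nc3ccc(F)c(Cl)c3)c2cc1NC(=O)N/N=C/c1ccc(O)c(Br)c1`) replaces hydrogen with hydroxy on an aromatic carbon, turning 3-bromophenyl into 3-bromo-4-hydroxyphenyl: hydroxy in place of hydrogen on an aromatic carbon. Among the measured compounds shown here, no measured step shows the effect of this change. Only a modest move toward stronger inhibition in this assay is expected, with any number landing near compound 2 at 15500 nM, and another report without a number remains quite possible. The estimated value for compound 4 is 20000 nM, with an expected range of 6000 nM to 60000 nM.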

Compound 4, half-maximal inhibitory concentration: 15300 nM
Beside the measured number, compound 4's estimate is 1.3-fold (0.12 log units) above it, and the stated range covers the measured number.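

Among the compounds shown here, compound 3 reads "not active" (no number reported) in this assay and compound 4 gives 15300 nM there, so no step between compound 3 and compound 4 can be read. What hydroxy in place of hydrogen does to potency stays open, and nothing shown here accounts for the result.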